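A few compounds are considered here, and "the series" means these few. Any claim that something is new, unique, unknown or untested is made for them only; others in the source may bear on it.

Measured so far:
compound 1 `COc1ccccc1N1CCN(C(=O)C2(C)CCc3c(C)c(O)c(C)c(C)c3O2)CC1` — 15000 nM
compound 2 `COc1ccc(N2CCN(C(=O)C3(C)CCc4c(C)c(O)c(C)c(C)c4O3)CC2)cc1` — 700 nM

Going by the values given here, in a functional assay (brain) for inhibition, with Rattus norvegicus as the target (a lower number here means a stronger inhibitor, a higher number a weaker inhibitor), compound 2 holds the lower of the two numbers; its only neighbour is compound 1, and a 21-fold lower number from compound 1 to compound 2 (1.33 log units; beyond the scatter). Compound 3 `Cc1c(C)c2c(c(C)c1O)CCC(C)(C(=O)N1CCNCC1)O2` differs from compound 2 by hydrogen in place of 4-methoxyphenyl on an amine nitrogen in a ring. Among the compounds with values here, the single measured step exchanges one methoxyphenyl for another and does not remove the aryl group, so it bears on this change only loosely, though it shows that this amine nitrogen moves the readout strongly. A large step is therefore expected, most plausibly toward a weaker inhibitor: an 8.6-fold higher number from compound 2 to compound 3 (0.93 log units; beyond the scatter). Compound 3 is estimated at 6000 nM, within 1200 nM to 30000 nM.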

Compound 3, half-maximal inhibitory concentration: 10000 nM
Compound 3: middle estimate off by 1.7-fold (0.22 log units), on the low side; the measured number falls inside the stated range.
By their numbers in this assay, from the lowest: compound 2; then compounds 3 and 1 (each within the scatter of the next).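

In this assay the 4-methoxyphenyl on this amine nitrogen proves better than no aryl group at all (a 14-fold higher number from compound 2 to compound 3 (1.15 log units; beyond the scatter)). The 2-methoxyphenyl shows no such advantage (a 1.5-fold lower number from compound 1 to compound 3 (0.18 log units; within the scatter)), so hydrogen and 2-methoxyphenyl read alike here, and only the 4-methoxyphenyl separates from hydrogen. Still open, from the compounds shown here alone, is whether the number of compound 2 depends on the methoxy group or is held by a plain phenyl, and whether a benzyl or a methyl on this nitrogen behaves like the aryl groups or like hydrogen. No measurement at hand explains the difference between the two methoxyphenyl groups.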